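The source may report more compounds than this note shows. Statements on the series, on what has been measured and on what is new or still open speak of the compounds shown alone.

Compound 1 `CCC(=O)N(c1ccc(Cl)cc1)C1CCCC1N(C)C`: 0.2 mg/kg
Compound 2 `CCC(=O)N(c1ccc(Br)cc1)C1CCCC1N(C)C`: 3 mg/kg

In a functional assay on the whole organism for antagonist activity, with Mus musculus as the target (a higher number here means that more compound is needed for the effect, a lower number that less compound is needed), compound 2 has the higher of the two numbers, at 3 mg/kg. Compound 3 `CCC(=O)N(c1ccc([N+](=O)[O-])cc1)C1CCCC1N(C)C` has nitro in place of bromo on an aromatic carbon. Among the measured compounds shown here, one measured step bears on this change, at the same place: a 15-fold higher number from compound 1 to compound 2 (1.18 log units; beyond the scatter), which is large and beyond the scatter. That single step shows that a swap here can move the number far, but it gives no firm direction for nitro. The expected change is a 2.5-fold lower number from compound 2 to compound 3 (0.40 log units; beyond the scatter), a moderate step to a lower number, with the direction uncertain. For compound 3 the estimate is 1.2 mg/kg, with an expected range of 0.2 mg/kg to 7 mg/kg.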

Compound 3, dose for half-maximal effect: 6 mg/kg
The estimate for compound 3 lay 5.0-fold (0.70 log units) below the measured number, and the stated range covers the measured number.
By their numbers in this assay, from the lowest: compound 1; then compounds 2 and 3 (each within the scatter of the next).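

In this assay the replacement of bromo by nitro gives a 2.0-fold higher number from compound 2 to compound 3 (0.30 log units; within the scatter) and so does not separate these two groups at this place on the aromatic ring. The other comparison reads a 30-fold higher number from compound 1 to compound 3 (1.48 log units; beyond the scatter) and shows a second group, after bromo, standing well apart from chloro. No measurement on hand accounts for this gap.

On these data alone, how fluoro, a methoxy group or an amine at this same place would stand against chloro stays open. Also open, as far as these compounds go, is whether the gap between chloro and the other two groups persists when the shared core is changed elsewhere.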